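Shortening the amide group: what compound 3 may do

A few compounds are considered here, and "the series" means these few. Any claim that something is new, unique, unknown or untested is made for them only; others in the source may bear on it.

Within the data shown here, in a functional assay on PC-3 cells (Homo sapiens) for antiproliferative activity, read by MTT assay, with a stated time of 24 h (a higher number here means a weaker inhibitor, a lower number a stronger inhibitor), compound 2 `CCn1c(C(=O)N[C@H](CO)CCCO)ccc1C(CC)(CC)c1ccc(OCS(=O)(=O)c2ccccc2)c(C)c1` gives 6810 nM, the only true number so far. Compound 1 `CCn1c(C(=O)N[C@@H](C)C(=O)OC)ccc1C(CC)(CC)c1ccc(OCS(=O)(=O)c2ccccc2)c(C)c1` gives > 50000 nM, which is a limit of the assay and not a number. Among the measured compounds shown here, the single measured step, an at least 7.3-fold lower number from compound 1 to compound 2 (0.86 log units; beyond the scatter), came with a group of 7 heavy atoms replacing a group of 6 heavy atoms on an amide-type nitrogen.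

Compound 3 `CCn1c(C(=O)NCC(=O)O)ccc1C(CC)(CC)c1ccc(OCS(=O)(=O)c2ccccc2)c(C)c1` keeps the shared core but carries carboxymethyl on that amide-type nitrogen, in place of the group of 7 heavy atoms in compound 2: a group of 4 heavy atoms (2 carbon, 2 oxygen; no ring) in place of a group of 7 heavy atoms (5 carbon, 2 oxygen; no ring), on an amide-type nitrogen. This change runs the other way in group size, so it is reasonable to expect some of the gain seen in that single step to be lost. One step is thin guidance, however, and the new group differs in kind as well as in size. The expected change, toward a weaker inhibitor in this assay, is a 4.1-fold higher number from compound 2 to compound 3 (0.61 log units; beyond the scatter). For compound 3 the estimated value is 28000 nM, with an expected range from 9000 nM to 50000 nM.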

Compound 3, half-maximal inhibitory concentration: 30100 nM
Compound 3: the middle estimate sits 1.1-fold (0.03 log units) below what was measured; low and high end bracket the measured number.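

In this assay, the amide-type nitrogen now has a second true number, and the step, a 4.4-fold higher number from compound 2 to compound 3 (0.65 log units; beyond the scatter), shows that carboxymethyl in place of the larger group of compound 2 goes with a modest loss, beyond the scatter. Among these compounds, this is the first change at this position that can be sized between two real numbers and not against a limit. The comparison with the other neighbour, an at least 1.6-fold lower number from compound 1 to compound 3 (0.22 log units; that floor lies within the scatter), gives no firm order for that pair, since the entry for compound 1 is a limit and not a number, and the step rests on it: the limit of > 50000 nM in this assay, at which 1 of the 3 values shown sits.

Group size and kind of group change together across these compounds, so it remains open whether the number follows the count of heavy atoms on the nitrogen, the particular atoms in the group, or both. A plain ethyl group, a longer chain ending in a carboxylic acid, or a chain ending in an amine, each on the same amide-type nitrogen, would help to separate these readings.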